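From pyridin-4-yl to 4-carbamoylphenyl on the shared core

This account rests on a few compounds, and the source may have more. Where it says the series, first, only, none or still open, it means among the compounds named here.

Values in a physicochemical assay for solubility, using the shake flask method, in simulated intestinal fluid, measured as kinetic solubility, with a stated time of 2 h, at 25 degrees C, at pH 6.5; on this read-out higher numbers stand for higher solubility and lower numbers for lower solubility:
- compound 1 `Cc1noc(-c2nc(C)c3c(c2N)C(=O)N(Cc2cccc(F)c2)C3=O)n1` gives < 5000 nM, a limit
- compound 2 `Cc1noc(-c2nc(C)c3c(c2N)C(=O)N(Cc2ccc(OC(F)F)cc2)C3=O)n1` gives < 5000 nM, a limit
- compound 3 `Cc1noc(-c2nc(C)c3c(c2N)C(=O)N(Cc2ccncc2)C3=O)n1` gives 26400 nM

For the measured compounds named here, compound 3 holds the only true number in this set, and the other two stand at the limit of < 5000 nM in this assay, at which 2 of the 3 values shown sit. Compound 4 `Cc1noc(-c2nc(C)c3c(c2N)C(=O)N(Cc2ccc(C(N)=O)cc2)C3=O)n1` carries 4-carbamoylphenyl in place of pyridin-4-yl on a saturated chain carbon bound to an amide-type nitrogen in a ring.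

Going by the values given here, two measured steps bear on this change, each starting from a ring of carbon only and ending at compound 3: an at least 5.2-fold higher number from compound 1 to compound 3 (0.72 log units; beyond the scatter) and an at least 5.2-fold higher number from compound 2 to compound 3 (0.72 log units; beyond the scatter). The step that the two limits leave unreadable from compound 1 to compound 2 gives no usable size. Among the compounds with values here, no measured compound carries the carbamoyl group, so the transfer is uncertain.

Compound 4 also has a ring of carbon only, so a modest move towards lower numbers is expected in this assay. The expected change is a 3.8-fold lower number from compound 3 to compound 4 (0.58 log units; beyond the scatter). For compound 4 the estimated value is 7000 nM, with an expected range from 2500 nM to 25000 nM.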

Compound 4, solubility: < 5000 nM
Compound 4 gave a limit, no number; the forecaster's own chance of this, stated with the estimate: 45%; middle value at least 1.4-fold (0.14 log units) from the limit.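

In this assay the change to 4-carbamoylphenyl on a saturated chain carbon bound to an amide-type nitrogen in a ring gives an at least 5.2-fold lower number from compound 3 to compound 4 (0.72 log units; beyond the scatter). Compound 4 gives < 5000 nM, a limit and not a number, so all three compounds shown with a ring of carbon only at this position now stand at a limit, including the one carrying a carbamoyl group with its hydrogen-bond donor. The steps among compound 1, compound 2 and compound 4 cannot be read, and compound 3 remains the only true number in the set, with the others at this point: the limit of < 5000 nM in this assay, at which 3 of the 4 values shown sit.

As far as these compounds go, it stays open whether a readable number at this position belongs to pyridin-4-yl alone, or whether a carboxylic acid or an amine in place of the carbamoyl group would also give one. From the compounds shown here alone, the full size of the gap between compound 3 and the compounds at the limit also stays open.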